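Swapping a benzyl for an aryl group on the terminal amide

The source may hold more compounds than are shown below. What is called first, only, known or untested is meant among the compounds shown, and "the series" means these compounds.

Of the compounds shown here, three have been measured in a functional assay on THP-1 cells (Homo sapiens) for inhibition; a lower number here means a stronger inhibitor, a higher number a weaker inhibitor. Compound 1 `Cc1c(C(=O)N[C@H](C(=O)NC(CC(=O)O)C(=O)CF)C(C)C)n(C)c2ccccc12` gives 10000 nM, compound 3 `C[C@H](NC(=O)C(=O)Nc1cc(C(C)(C)C)ccc1C(C)(C)C)C(=O)N[C@@H](CC(=O)O)C(=O)COc1c(F)c(F)cc(F)c1F` gives 1840 nM, and compound 2 `C[C@H](NC(=O)C(=O)NCc1ccccc1)C(=O)N[C@@H](CC(=O)O)C(=O)COc1c(F)c(F)cc(F)c1F` gives 160 nM, the lowest of the three numbers, with the step to compound 3 and the step to compound 1 both beyond the usual scatter. Compound 4 `C[C@H](NC(=O)C(=O)Nc1ccccc1-c1ccc[nH]1)C(=O)N[C@@H](CC(=O)O)C(=O)COc1c(F)c(F)cc(F)c1F` is not yet measured; it carries 2-(1H-pyrrol-2-yl)phenyl in place of benzyl on an amide-type nitrogen. Going by the values given here, the only guide is compound 3, which also carries a different group on that same amide-type nitrogen and sits at 1840 nM. Compound 4 is therefore expected to give a somewhat higher number than compound 2, estimated as 450 nM, within a range of 130 nM to 1600 nM. The step from compound 2 to compound 4 is expected to be a 2.8-fold higher number from compound 2 to compound 4 (0.45 log units; beyond the scatter), a loss beyond the scatter but smaller than that seen for compound 3.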

Compound 4, half-maximal inhibitory concentration: > 32000 nM
Compound 4: only a limit was reported (the forecaster's own chance of this, stated with the estimate: 5%); at least 71-fold (1.85 log units) between middle value and limit.
By their numbers in this assay, from the lowest: compound 2; then compound 3; then compound 1. At a limit, above all of these: compound 4.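

Putting 2-(1H-pyrrol-2-yl)phenyl in place of benzyl on the amide-type nitrogen gives an at least 200-fold higher number from compound 2 to compound 4 (2.30 log units; beyond the scatter), a large step that shows this position can lose nearly all measurable inhibition, not just part of it. In this assay compound 4 gives > 32000 nM, which is a limit of the assay and not a number: the limit of > 32000 nM in this assay, at which 1 of the 4 values shown sits.

The compounds shown leave open which part of the change matters, the loss of the benzyl carbon that links the ring to the nitrogen or the added five-membered aromatic ring. A plain phenyl group on that nitrogen would separate the two.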